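The source may report more compounds than this note shows. Statements on the series, on what has been measured and on what is new or still open speak of the compounds shown alone.

Compound 2 `COc1cc(CCc2cccc(O)c2)c(Cc2ccc(O)cc2)c(O)c1Cc1ccc(O)cc1` gives 1100 nM in a functional assay on cells (Neutrophil, Homo sapiens) for inhibition, read by spectrophotometry, with a stated time of 5 min (on this read-out higher numbers stand for weaker inhibition and lower numbers for stronger inhibition), and compound 1 `COc1cc(CCc2cccc(O)c2)cc(O)c1Cc1ccc(O)cc1` gives 2200 nM, so compound 2 stands nearest compound 1 with the two numbers within the scatter of each other, as a 2.0-fold lower number from compound 1 to compound 2 (0.30 log units; within the scatter) shows. Compound 3 `COc1cc(O)c(Cc2ccc(O)cc2)c(CCc2cccc(O)c2)c1` differs from compound 2 by hydrogen in place of 4-hydroxybenzyl on an aromatic carbon. Among the compounds with values here, the one step that bears on this change, a 2.0-fold lower number from compound 1 to compound 2 (0.30 log units; within the scatter), added a 4-hydroxybenzyl without moving the number beyond the scatter, so taking one away is expected to do likewise in this assay. The expected step is a 1.6-fold higher number from compound 2 to compound 3 (0.21 log units; within the scatter), within the scatter. Compound 3 is therefore estimated at 1800 nM, between 800 nM and 4500 nM.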

Compound 3, half-maximal inhibitory concentration: 3600 nM
Estimate against measurement, compound 3: 2.0-fold (0.30 log units) below; the range from low to high includes it.
By their numbers in this assay, from the lowest: compounds 2, 1 and 3 (each within the scatter of the next, the first and the last beyond it).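

Taking away the 4-hydroxybenzyl that stands ortho to a hydroxy group and ortho to a methoxy group gives a 3.3-fold higher number from compound 2 to compound 3 (0.51 log units; beyond the scatter) in this assay and so weakens inhibition modestly. This is the first step among these compounds to pass beyond the scatter, and it shows that a 4-hydroxybenzyl at this position can count. Nothing available explains the size of this step. The compounds shown leave open whether the hydroxy group of the benzyl matters here, and whether a plain benzyl, a methyl or a carboxylic acid at this carbon would hold the number of compound 2.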